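Solubility of a Spirocyclic Amine Analogue of Compound 3

The source may report more compounds than this note shows. Statements on the series, on what has been measured and on what is new or still open speak of the compounds shown alone.

Compound 1 `COc1ccc2[nH]c(C(=O)N3CC(=O)N(Cc4ccccc4)[C@@H](COc4ccccc4)C3)cc2c1`: 12200 nM
Compound 2 `COc1ccc2[nH]c(C(=O)N3CC(=O)N(Cc4ccccc4)[C@@H](CN4CCCCC4)C3)cc2c1`: a limit, > 25000 nM
Compound 3 `COc1ccc2[nH]c(C(=O)N3CC(=O)N(Cc4ccccc4)[C@@H](CN4CCC(C)CC4)C3)cc2c1`: 93100 nM

In a physicochemical assay for solubility, read by spectrophotometry, in phosphate buffer, with a stated time of 2 h, at pH 7.4 (on this read-out lower numbers stand for lower solubility and higher numbers for higher solubility), compound 1 gives 12200 nM. For compound 2 this assay reports only a limit, > 25000 nM. Compound 3 gives 93100 nM, the highest of the two numbers shown, with a 7.6-fold higher number from compound 1 to compound 3 (0.88 log units; beyond the scatter). The two readable steps both replaced phenoxy by an amine: an at least 2.0-fold higher number from compound 1 to compound 2 (0.31 log units; beyond the scatter) and a 7.6-fold higher number from compound 1 to compound 3 (0.88 log units; beyond the scatter), while a step that the limit leaves unreadable from compound 2 to compound 3, as the limit of > 25000 nM in this assay, at which 1 of the 3 values shown sits, leaves that step unreadable.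

Compound 4 `COc1ccc2[nH]c(C(=O)N3CC(=O)N(Cc4ccccc4)[C@@H](CCN4CCC5(CC4)CC5)C3)cc2c1` differs from compound 3 by a group of 9 heavy atoms (8 carbon, 1 nitrogen; one three-membered non-aromatic ring of carbon only, one six-membered non-aromatic ring with 1 hetero atom) in place of a group of 7 heavy atoms (6 carbon, 1 nitrogen; one six-membered non-aromatic ring with 1 hetero atom), on a saturated chain carbon bound to a saturated ring carbon. Within the data shown here, an amine stays in place, so no measured step argues for a large move; the expected step is a 1.6-fold lower number from compound 3 to compound 4 (0.19 log units; within the scatter). Compound 4 is therefore estimated at 60000 nM, within 20000 nM to 150000 nM.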

Compound 4, solubility: > 25000 nM
Compound 4: only a limit was reported; the forecaster's own chance of this, stated with the estimate: 10%; the middle value lies beyond the limit too.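

For compound 4, this assay reports only a limit, > 25000 nM. The larger amine with its three-membered ring still leaves phenoxy behind on this read-out, with an at least 2.0-fold higher number from compound 1 to compound 4 (0.31 log units; beyond the scatter), so all three amines shown now give higher numbers than the phenoxy group. The steps among these amines that involve a limit cannot be read, because of the limit: the limit of > 25000 nM in this assay, at which 2 of the 4 values shown sit.

As far as these compounds go, how the amines rank against one another therefore stays open. So does whether a morpholine or a carboxylic acid at this place would also exceed phenoxy.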